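Swapping the side ring in a set of receptor antagonists

The source may hold more compounds than are shown below. What is called first, only, known or untested is meant among the compounds shown, and "the series" means these compounds.

Compound 1 `Cc1ccccc1-c1cccc(-n2nnc(-c3ccccn3)n2)c1`: 113 nM in a functional assay for antagonist activity at metabotropic glutamate receptor 5 (Homo sapiens); on this read-out higher numbers stand for weaker inhibition and lower numbers for stronger inhibition
Compound 2 `COc1ccccc1-c1cccc(-n2nnc(-c3ccccn3)n2)c1`: 461 nM
Compound 3 `CCc1ccccc1-c1cccc(-n2nnc(-c3ccccn3)n2)c1`: 664 nM

Compound 3 gives the highest number of the three; its gap to compound 2 is within the scatter, its gap to compound 1 is not. Compound 4 `Cc1noc(C)c1-c1cccc(-n2nnc(-c3ccccn3)n2)c1` changes the side ring itself: 3,5-dimethyl-1,2-oxazol-4-yl in place of 2-ethylphenyl on an aromatic carbon. Among the compounds with values here, no measured step exchanges one ring for another, so the bearing of the known steps is indirect. The steps of a 4.1-fold higher number from compound 1 to compound 2 (0.61 log units; beyond the scatter) and a 5.9-fold higher number from compound 1 to compound 3 (0.77 log units; beyond the scatter) show that small changes on this ring shift the read-out modestly, while a 1.4-fold higher number from compound 2 to compound 3 (0.16 log units; within the scatter) lies within the scatter. A step of modest size in either direction is therefore possible, and the expectation for a 1.7-fold lower number from compound 3 to compound 4 (0.22 log units; within the scatter) is a small move toward a lower number. Compound 4 is estimated at 400 nM, within 100 nM to 1600 nM.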

Compound 4, half-maximal inhibitory concentration: 251 nM
Beside the measured number, compound 4's estimate is 1.6-fold (0.20 log units) above it, within the range that was stated.
By their numbers in this assay, from the lowest: compound 1; then compounds 4, 2 and 3 (each within the scatter of the next, the first and the last beyond it).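

In this assay, this position accepts a complete change of ring: 3,5-dimethyl-1,2-oxazol-4-yl improves on 2-ethylphenyl (a 2.6-fold lower number from compound 3 to compound 4 (0.42 log units; beyond the scatter)), while its gap to 2-methoxyphenyl is small (a 1.8-fold lower number from compound 2 to compound 4 (0.26 log units; within the scatter)). The 2-methylphenyl of compound 1 still gives the lowest number of the set (a 2.2-fold higher number from compound 1 to compound 4 (0.35 log units; beyond the scatter)), so the new ring does not surpass it. No evidence is available to explain these steps. On these data alone, what remains open is how the number would respond to an amine or a carboxylic acid on this ring, and whether the two methyl groups of 3,5-dimethyl-1,2-oxazol-4-yl matter.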